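The source may report more compounds than this note shows. Statements on the series, on what has been measured and on what is new or still open speak of the compounds shown alone.

Two compounds give a first view of this small series, both carrying the same shared core. Compound 1 `Cc1ccc(-n2cc(CSC(=S)N3CCN(C(=O)OC(C)(C)C)CC3)nn2)cc1` gives 74200 nM in a functional assay on MCF7 cells (Homo sapiens) for inhibition, read by MTT assay, with a stated time of 72 h; on this read-out lower numbers stand for stronger inhibition and higher numbers for weaker inhibition. Compound 2 `O=C(OCc1ccccc1)N1CCN(C(=S)SCc2cn(Cc3ccccc3Cl)nn2)CC1` gives 21400 nM in this assay. Compound 1 thus has the highest number of the two, and the gap to compound 2 lies beyond the usual scatter; since the two differ in several places at once, only their two values can be compared, and no single change can be singled out.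

The unmeasured compound 3 `Cc1ccc(Cn2cc(CSC(=S)N3CCN(C(=O)OC(C)(C)C)CC3)nn2)cc1` is related to compound 1 by a single change: 4-methylbenzyl in place of 4-methylphenyl on an aromatic nitrogen. Within the data shown here, no measured pair in the set shows this exact change, so the size of its step is not known. Among the measured compounds shown here, compound 2, the one compound that carries a benzyl-type group on that ring nitrogen, gives the lower number, which gives a cautious hint toward a modest decrease. Compound 3 is therefore expected to show the step of a 1.6-fold lower number from compound 1 to compound 3 (0.22 log units; within the scatter). The expected value of compound 3 in this assay is 45000 nM, with a range from 18000 nM to 110000 nM.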

Compound 3, half-maximal inhibitory concentration: 19700 nM
Compound 3: middle estimate off by 2.3-fold (0.36 log units), on the high side; the range from low to high includes it.
By their numbers in this assay, from the lowest: compounds 3 and 2 (each within the scatter of the next); then compound 1.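

Among these compounds, the step gives this position a measured size for the first time: in this assay, putting 4-methylbenzyl in place of 4-methylphenyl on the aromatic nitrogen gives a 3.8-fold lower number from compound 1 to compound 3 (0.58 log units; beyond the scatter), a modest change that lies beyond the usual scatter. The earlier pair differed in several places at once, so it could not link any difference in their numbers to this nitrogen alone. Here the rest of the molecule stays the same, the group keeps its six-membered aromatic ring and goes only from 7 heavy atoms to 8, yet nothing available explains why the number falls.

One pair cannot show whether the same step would appear when other parts of the molecule are changed, or whether the methyl group on the aromatic ring has any part in it. As far as these compounds go, how the number would respond to a longer chain on this nitrogen, such as 2-phenylethyl, or to an amine or a carboxylic acid on the aromatic ring in place of the methyl group, also remains open.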